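Phenyl for Bromo: One Change Tried on Two Chains

The compounds below may be only part of what the source reports. "The series", "measured", "known", "first", "only" and "open" are said of these compounds alone.

Of the compounds shown here, three are measured so far, all built on a sulfonamide joined through a chain to a triazole that carries a pyridyl group. Compound 1 `O=S(=O)(NCCCCCCCCn1cc(-c2cccnc2)nn1)c1ccccc1Br` carries a bromo group on its core. In a functional assay on SH-SY5Y cells (Homo sapiens) for cytotoxicity, read by MTT assay, with a stated time of 56 h (on this read-out lower numbers stand for an effect already at smaller amounts and higher numbers for an effect only at larger amounts of compound), compound 1 gives 171 nM. Compound 2 `O=S(=O)(NCCCCCCCn1cc(-c2cccnc2)nn1)c1ccccc1Br` is a close relative; the difference between the two cores is not broken down here. In this assay, for the measured compounds named here, compound 2 gives 162 nM, a number within the usual scatter of the one for compound 1. Compound 3 `O=S(=O)(NCCCCCCCCn1cc(-c2cccnc2)nn1)c1ccccc1-c1ccccc1` arises from compound 1 by a single change.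

phenyl in place of bromo on an aromatic carbon

That change made a 14-fold lower number from compound 1 to compound 3 (1.13 log units; beyond the scatter), so in this assay compound 3 gives 12.6 nM.

Compound 4 `O=S(=O)(NCCCCCCCn1cc(-c2cccnc2)nn1)c1ccccc1-c1ccccc1` is not yet measured. It stands to compound 2 exactly as compound 3 stands to compound 1.

phenyl in place of bromo on an aromatic carbon

The place described for both changes is the same word for word, so this is the same change, only made on the core of compound 2 rather than that of compound 1. Since the starting numbers of compound 1 and compound 2 lie within the scatter of each other, the same change is expected to give a step of similar size: the expected step is a 14-fold lower number from compound 2 to compound 4 (1.13 log units; beyond the scatter), set beside the measured 14-fold lower number from compound 1 to compound 3 (1.13 log units; beyond the scatter). This rests on a single measured pair, so the range is kept wide. Compound 4 is therefore estimated at 12 nM, with 5 nM to 30 nM expected to hold most repeat measurements.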

Compound 4, half-maximal effective concentration: 99.2 nM
Compound 4: middle estimate off by 8.3-fold (0.92 log units), on the low side; the measured number lies above the stated range.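

In this assay, for the compounds shown here, putting phenyl in place of bromo on the core of compound 2 gives a 1.6-fold lower number from compound 2 to compound 4 (0.21 log units; within the scatter), so on this core the change leaves no step that can be told apart from ordinary repeat variation. Set beside the earlier result, this shows that the change does not carry over from one core to the other with the same size, even though the two bromo starting compounds, compound 1 and compound 2, lie within the scatter of each other, and the gap between the two steps is itself a real one: the same change on two cores in this assay, a 14-fold lower number (1.13 log units; beyond the scatter) from compound 1 to compound 3 and a 1.6-fold lower number (0.21 log units; within the scatter) from compound 2 to compound 4, 8.3-fold (0.92 log units) apart, beyond the scatter of two such steps. Going by these compounds alone, it does not show why the two cores respond so differently, and with only one measured pair on each core it gives no rule for what the same change would do on any further core.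

The compounds shown leave open whether the large step seen on the core of compound 1 would return on a longer chain, or whether it belongs to that core alone. They also leave open how a group other than phenyl or bromo on the same aromatic carbon, such as an amine or a carboxylic acid, would behave on these two cores.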